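Compound 3 to compound 4: chloro on the anilino group

The compounds below may be only part of what the source reports. "The series", "measured", "known", "first", "only" and "open" are said of these compounds alone.

In an ADME assay on BHK-21 cells (Mesocricetus auratus) for cytotoxicity, read by MTT assay, with a stated time of 72 h (on this read-out higher numbers stand for lower toxicity in this test and lower numbers for higher toxicity in this test), compound 1 `Cc1ccc(NCc2cn(-c3ccccc3)nc2-c2ccc(C)cc2)cc1` gives > 100000 nM, a limit of the assay. Compound 3 `Cc1ccc(-c2nn(-c3ccccc3)cc2CNc2ccccc2)cc1` gives > 100000 nM, also a limit. Compound 3 thus stands at the limit of > 100000 nM in this assay, at which 2 of the 3 values shown sit, and has no number of its own. Among the compounds with values here, compound 2 `Clc1ccc(NCc2cn(-c3ccccc3)nc2-c2ccc(Cl)cc2)cc1`, which carries (4-chlorophenyl)amino, gives 73000 nM, the only value so far that is a number.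

Compound 4 `Cc1ccc(-c2nn(-c3ccccc3)cc2CNc2ccc(Cl)cc2)cc1` arises from compound 3 by chloro in place of hydrogen on an aromatic carbon, with anilino becoming (4-chlorophenyl)amino. Within the data shown here, the one measured step on this group, a step that the two limits leave unreadable from compound 1 to compound 3, offers no size to carry over. Among the measured compounds shown here, the only guide is therefore compound 2 at 73000 nM, and it is an indirect one. In this assay a small move towards lower numbers is expected, though compound 4 may well stay at the limit. The estimated step is an at least 1.1-fold lower number from compound 3 to compound 4 (0.07 log units; that floor lies within the scatter). For compound 4 the expected value is 85000 nM, with an estimated range of 50000 nM to 100000 nM.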

Compound 4, half-maximal cytotoxic concentration: > 100000 nM
Compound 4: only a limit was reported (the forecaster's own chance of this, stated with the estimate: 45%); middle value at least 1.1-fold (0.07 log units) away from the limit.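

In this assay compound 4 gives > 100000 nM, a limit of the assay, so chloro on the anilino group, with the methyl of compound 3 kept, does not bring a number into range. Methyl in place of chloro leading to compound 4 gives an at least 1.3-fold higher number from compound 2 to compound 4 (0.13 log units; that floor lies within the scatter), so compound 2, the one compound with a number, cannot yet be told apart from compound 4. The steps to compound 4 from compound 1 and from compound 3 cannot be read, and most of the series now rests on a single ceiling: the limit of > 100000 nM in this assay, at which 3 of the 4 values shown sit.

As far as these compounds go, the true size of the chloro step on the anilino group stays open. So does whether an amine or a carboxylic acid in that place would give a number under the limit.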